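Swapping Trifluoromethyl for Methyl on a Shared Core

A few compounds are considered here, and "the series" means these few. Any claim that something is new, unique, unknown or untested is made for them only; others in the source may bear on it.

Of the compounds shown here, two built on the same core have been measured in a functional assay on MCF7 cells (Homo sapiens) for antiproliferative activity, read by MTT assay; on this read-out lower numbers stand for stronger inhibition and higher numbers for weaker inhibition. Compound 1 `COc1ccc(Nc2ccnc(Nc3ccc(NS(=O)(=O)c4ccc(OC)cc4)cc3)n2)cc1` gives 29000 nM. Compound 2 `COc1ccc(Nc2ccnc(Nc3ccc(NS(=O)(=O)c4ccc(C(F)(F)F)cc4)cc3)n2)cc1` gives 34800 nM, the higher of the two numbers, although the gap between them, a 1.2-fold higher number from compound 1 to compound 2 (0.08 log units; within the scatter), lies within the scatter of repeated measurements. Compound 2 thus stands at the top of a pair whose members cannot really be told apart, and both sit in a weakly inhibiting range.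

Compound 3 `COc1ccc(Nc2ccnc(Nc3ccc(NS(=O)(=O)c4ccc(C)cc4)cc3)n2)cc1` is not yet measured. It differs from compound 2 in one place: methyl in place of trifluoromethyl on an aromatic carbon. For the measured compounds named here, this change sits on an aromatic carbon of a six-membered aromatic ring of carbon only, para to a large group, the very position where the single known step was made. That step, methoxy to trifluoromethyl, moved the number only within the scatter, so a further swap at the same spot, to methyl, gives no reason to expect a shift in this assay beyond the scatter in either direction.

Compound 3 is therefore expected to come out at 30000 nM, with a likely range from 12000 nM to 75000 nM. The expected step is a 1.2-fold lower number from compound 2 to compound 3 (0.06 log units; within the scatter), essentially no change.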

Compound 3, half-maximal inhibitory concentration: > 50000 nM
Compound 3 gave a limit, no number; the forecaster's own chance of this, stated with the estimate: 10%; middle value at least 1.6-fold (0.22 log units) from the limit.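

In this assay compound 3 gives > 50000 nM, which is a limit of the assay and not a number. Methyl on this aromatic carbon therefore adds two steps that have a floor but no ceiling, an at least 1.4-fold higher number from compound 2 to compound 3 (0.15 log units; that floor lies within the scatter) and an at least 1.7-fold higher number from compound 1 to compound 3 (0.23 log units; that floor lies within the scatter): both point towards weaker inhibition, and neither floor alone separates methyl from the other two groups. The earlier pair, with its single step of a 1.2-fold higher number from compound 1 to compound 2 (0.08 log units; within the scatter), made this position look indifferent to the group placed on it, but that reading is no longer secure, since the methyl compound is the one member of the series that reaches the end of the measurable range: the limit of > 50000 nM in this assay, at which 1 of the 3 values shown sits.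

Going by these compounds, without an actual number for compound 3, it remains open whether methyl truly differs from methoxy and trifluoromethyl or stays within the usual scatter of them. The compounds shown also leave open how an amine, a carboxylic acid or a longer chain such as ethyl on this same aromatic carbon would read, and whether any group here can bring the shared core out of its weakly inhibiting range.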